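Methoxy added to a pyrazolyl chalcone: an expected step

The source may report more compounds than this note shows. Statements on the series, on what has been measured and on what is new or still open speak of the compounds shown alone.

The account concerns four chalcone-type compounds sharing a pyrazole linked to an enone. Compound 1 `COc1ccc(-c2cc(/C=C/C(=O)c3ccc(N)cc3)[nH]n2)cc1` and compound 3 `COc1ccc(-c2cc(/C=C/C(=O)c3ccc(N)cc3)[nH]n2)cc1OC` differ by methoxy in place of hydrogen on an aromatic carbon, and in a functional assay on MDA-MB-435 cells (Homo sapiens) for inhibition, read by sulforhodamine B assay, with a stated time of 48 h (a higher number here means a weaker inhibitor of growth, a lower number a stronger inhibitor of growth), compound 1 gives 7000 nM while compound 3 gives 7230 nM; the step of a 1.0-fold higher number from compound 1 to compound 3 (0.01 log units; within the scatter). Compound 2 `COc1ccc(C(=O)/C=C/c2cc(-c3cc(OC)c(OC)c(OC)c3)n[nH]2)cc1OC` is built on a different core; the difference between the two cores is not broken down here. In this assay compound 2 gives 2710 nM, the lowest of the three numbers, and its gaps to compound 1 and compound 3 lie beyond the scatter. Compound 4 `COc1cc(C(=O)/C=C/c2cc(-c3cc(OC)c(OC)c(OC)c3)n[nH]2)cc(OC)c1OC` has not yet been measured. It differs from compound 2 by methoxy in place of hydrogen on an aromatic carbon, the same kind of change as from compound 1 to compound 3, though here the place is also meta to a methoxy group. Because a 1.0-fold higher number from compound 1 to compound 3 (0.01 log units; within the scatter) stayed within the scatter, the step from compound 2 to compound 4 is expected to be a 1.0-fold higher number from compound 2 to compound 4 (0.01 log units; within the scatter). Compound 4 is therefore estimated to give 2800 nM in this assay, with a range from 1200 nM to 6500 nM.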

Compound 4, concentration for total growth inhibition: 2950 nM
For compound 4 the middle estimate is 1.1-fold (0.02 log units) below the measured one, and the stated range covers the measured number.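

In this assay the new step is a 1.1-fold higher number from compound 2 to compound 4 (0.04 log units; within the scatter), and it can be set beside the earlier step for methoxy in place of hydrogen on an aromatic carbon: the same change on two cores in this assay, a 1.0-fold higher number (0.01 log units; within the scatter) from compound 1 to compound 3 and a 1.1-fold higher number (0.04 log units; within the scatter) from compound 2 to compound 4, 1.1-fold (0.02 log units) apart, within the scatter of two such steps. Within these two pairs, then, the change carried from one core to the other with the same outcome, a step too small to separate from repeated measurement on either core. This does not show that the change is without consequence in general, as it rests on two pairs, with the place of the methoxy group not shown to be the same on both cores, and two steps within the scatter say little about how a larger step would carry over.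

From the compounds shown here alone, what a longer chain such as ethoxy, or a carboxylic acid, would do in the place taken by this methoxy group remains open. So does the gap between the two cores, as compound 2 differs from compound 1 and compound 3 in more than one place.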